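Acetyl in place of nitro: the step to compound 3

A few compounds are considered here, and "the series" means these few. Any claim that something is new, unique, unknown or untested is made for them only; others in the source may bear on it.

For the measured compounds named here, compound 2 `CC1(C)[C@@H]2CC[C@@]1(CS(=O)(=O)N1CCN(c3ccc([N+](=O)[O-])cn3)CC1)C(=O)C2` is one of only two compounds measured so far in a functional assay on CHO-K1 cells for antagonist activity at C-X-C chemokine receptor type 3 (Homo sapiens), read by FLIPR and calcium flux; on this read-out higher numbers stand for weaker inhibition and lower numbers for stronger inhibition. In this assay compound 2 gives > 31600 nM, which is a limit of the assay and not a number. Its neighbour compound 1 `CC1(C)[C@@H]2CC[C@@]1(CS(=O)(=O)N1CCN(c3ccccn3)CC1)C(=O)C2` differs from it by a nitro in place of hydrogen on an aromatic carbon. In this assay compound 1 gives > 31600 nM, again a limit. Going by the values given here, the one step measured, a step that the two limits leave unreadable from compound 1 to compound 2, therefore cannot be read in size, since (the limit of > 31600 nM in this assay, at which 2 of the 2 values shown sit).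

Compound 3 `CC(=O)c1ccc(N2CCN(S(=O)(=O)C[C@]34CC[C@H](CC3=O)C4(C)C)CC2)nc1` is not yet measured. It differs from compound 2 by acetyl in place of nitro on an aromatic carbon. Among the compounds with values here, no measured step bears directly on this change; the single step on record is unreadable, and both values around it sit at the limit of this assay. The expectation for compound 3 in this assay is therefore set near that limit, with a wide range, and the estimated step that the limit leaves unreadable from compound 2 to compound 3 is none beyond the scatter. Compound 3 is expected at 35000 nM, between 8000 nM and 100000 nM.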

Compound 3, half-maximal inhibitory concentration: > 31600 nM
Compound 3 gave a limit, no number; the forecaster's own chance of this, stated with the estimate: 80%; the middle value does not contradict the limit.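

No step among compound 1, compound 2 and compound 3 can be read in this assay, since each gives only a limit of the assay and no number: the limit of > 31600 nM in this assay, at which 3 of the 3 values shown sit.

The compounds shown leave open whether any group on this aromatic carbon, or any change elsewhere on the shared core, gives a measurable inhibition.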